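Aryl swap at the saturated ring carbon: cytotoxicity notes

The source may report more compounds than this note shows. Statements on the series, on what has been measured and on what is new or still open speak of the compounds shown alone.

Numbers so far in an ADME assay on Vero 76 cells (Chlorocebus sabaeus) for cytotoxicity, read by MTT assay, with a stated time of 96 h; a higher number here means that more compound is tolerated, a lower number that less compound is tolerated:

compound 1, `NS(=O)(=O)c1ccc(N2N=C(c3ccc(OCc4ccccc4)cc3)CC2c2ccc(F)cc2)cc1`: 90000 nM
compound 2, `NS(=O)(=O)c1ccc(N2N=C(c3ccc(OCc4ccccc4)cc3)CC2c2ccc(Cl)cc2)cc1`: 82000 nM
compound 3, `Cc1ccccc1C1CC(c2ccc(OCc3ccccc3)cc2)=NN1c1ccc(S(N)(=O)=O)cc1`: 100000 nM

Compound 3 has the highest of the three numbers, but the step of a 1.1-fold higher number from compound 1 to compound 3 (0.05 log units; within the scatter) and the step of a 1.2-fold higher number from compound 2 to compound 3 (0.09 log units; within the scatter) both lie within the scatter, so no order among the three is established. The step of a 1.1-fold lower number from compound 1 to compound 2 (0.04 log units; within the scatter) is likewise within the scatter.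

Compound 4, `NS(=O)(=O)c1ccc(N2N=C(c3ccc(OCc4ccccc4)cc3)CC2c2cccc(F)c2)cc1`, is not yet measured in this assay. It differs from compound 3 in one place: 3-fluorophenyl in place of 2-methylphenyl on a saturated ring carbon.

Among the compounds with values here, two measured steps bear directly on this change, since each replaces the aryl group on the same saturated ring carbon: a 1.1-fold higher number from compound 1 to compound 3 (0.05 log units; within the scatter) and a 1.2-fold higher number from compound 2 to compound 3 (0.09 log units; within the scatter). Both are within the scatter. The third step, a 1.1-fold lower number from compound 1 to compound 2 (0.04 log units; within the scatter), exchanges one halogen for another on an aromatic carbon and is also within the scatter. Three aryl groups at this position therefore give indistinguishable numbers in this assay, and the change to 3-fluorophenyl gives no reason to expect anything different. For compound 4 the expected step is a 1.1-fold lower number from compound 3 to compound 4 (0.05 log units; within the scatter), that is, none beyond the scatter. The estimate for compound 4 in this assay is 90000 nM, with a range from 60000 nM to 130000 nM.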

Compound 4, half-maximal cytotoxic concentration: 90000 nM
The estimate for compound 4 equals the measured number at the digits printed; low and high end bracket the measured number.
By their numbers in this assay, from the lowest: compounds 2, 1, 4 and 3 (each within the scatter of the next).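

Moving the fluorine from 4-fluorophenyl to 3-fluorophenyl gives no change at the digits printed from compound 1 to compound 4 (within the scatter) in this assay and so offers a comparison the earlier compounds did not: one substituent at two places on the same aryl group, with no difference beyond the scatter. The 3-fluorophenyl group also shows no difference beyond the scatter from the other two aryl groups, with a 1.1-fold lower number from compound 3 to compound 4 (0.05 log units; within the scatter) against 2-methylphenyl and a 1.1-fold higher number from compound 2 to compound 4 (0.04 log units; within the scatter) against 4-chlorophenyl. All four aryl groups on this saturated ring carbon next to the ring nitrogen therefore lie within the scatter of one another, and no data at hand offer an explanation for this.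

Going by these compounds, all four compounds carry an aryl group with a single halogen or methyl substituent at this position, so it remains open whether a carboxylic acid or an amine on that aryl group, or a cyclohexyl group in its place, would give a number outside the scatter of these four. On these data alone, the 4-sulfamoylphenyl group and the benzyloxy-bearing phenyl group are the same throughout, so what a change at either of those places does to the number in this assay also remains open.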